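This account rests on a few compounds, and the source may have more. Where it says the series, first, only, none or still open, it means among the compounds named here.

In a functional assay on A549 cells (Homo sapiens) for antiproliferative activity, read by MTT assay (on this read-out lower numbers stand for stronger inhibition and higher numbers for weaker inhibition), compound 1 `CC1(C)CCc2cc(C(=O)/C=C/c3ccc(OCc4cn(-c5ccc(Cl)cc5)nn4)cc3)c(O)cc2O1` gives 75500 nM and compound 2 `CC(=O)c1ccc(-n2cc(COc3ccc(/C=C/C(=O)c4ccc5c(c4O)CCC(C)(C)O5)cc3)nn2)cc1` gives 149000 nM in the same test. These two numbers lie within the usual scatter of each other, so compound 2 cannot be told apart from compound 1 on this evidence.

A third compound, compound 3 `CCCCCCCCn1cc(COc2ccc(/C=C/C(=O)c3ccc4c(c3O)CCC(C)(C)O4)cc2)nn1`, has not yet been measured. It keeps the rest of compound 2 but has octyl in place of 4-acetylphenyl on an aromatic nitrogen of a five-membered aromatic ring with 3 nitrogen, a difference counted as octyl in place of 4-acetylphenyl on an aromatic nitrogen in full.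

Going by the values given here, no two measured compounds differ in one place only, so the data give no direct guide to this exchange. With so little to go on, only a modest step towards stronger inhibition is expected in this assay, and it may not clear the scatter by much. The estimated change is a 2.5-fold lower number from compound 2 to compound 3 (0.40 log units; beyond the scatter) for this exchange. For compound 3 the expected value is 60000 nM on this reasoning. The estimated range for compound 3 runs from 20000 nM to 170000 nM in this test.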

Compound 3, half-maximal inhibitory concentration: "not active" (no number reported)
For compound 3 the study gives words and no number; there is nothing to compare the estimate with.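

In this assay, going by these compounds alone, compound 3 is reported only in words, as not active, so no step from compound 2 to compound 3 can be read. Nothing shown here explains this result. The compounds shown leave open how large the effect of octyl in place of 4-acetylphenyl on the aromatic nitrogen is on this read-out.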